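Methoxy for methyl on the sulfonyl ring of compound 1

A few compounds are considered here, and "the series" means these few. Any claim that something is new, unique, unknown or untested is made for them only; others in the source may bear on it.

Measured compounds:
compound 1 `Cc1ccc(S(=O)(=O)/C(=C/c2ccc(C)s2)C(=O)c2ccc(Cl)cc2)cc1` 50000 nM
compound 2 `CC(=O)Oc1ccc(/C=C(\C(=O)c2ccc(Cl)cc2)S(=O)(=O)c2ccc(C)cc2)cc1` 25000 nM
compound 3 `Cc1ccc(S(=O)(=O)/C(=C/c2ccc(O)c([N+](=O)[O-])c2)C(=O)c2ccc(Cl)cc2)cc1` 25000 nM

Of the compounds shown here, three sharing one core have been tested in a functional assay on DU-145 cells (Homo sapiens) for inhibition, read by trypan blue exclusion, with a stated time of 96 h; a higher number here means a weaker inhibitor of growth, a lower number a stronger inhibitor of growth. Compound 1 gives the highest of the three numbers, but both of its neighbours sit within the scatter: a 2.0-fold lower number from compound 1 to compound 2 (0.30 log units; within the scatter) and a 2.0-fold lower number from compound 1 to compound 3 (0.30 log units; within the scatter). Compound 2 and compound 3 are likewise indistinguishable, no change at the digits printed from compound 2 to compound 3 (within the scatter). Within the data shown here, all three therefore show the same weak inhibition of growth, and no compound can be called stronger or weaker than another.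

Compound 4 `COc1ccc(S(=O)(=O)/C(=C/c2ccc(C)s2)C(=O)c2ccc(Cl)cc2)cc1` has not yet been measured. It differs from compound 1 in a single place: methoxy in place of methyl on an aromatic carbon. The change sits on the 4-methylphenyl ring attached to the sulfonyl, whereas every measured step alters the aromatic group on the double-bonded chain carbon. Among the measured compounds shown here, none of the measured steps bears directly on this change, and all of them lie within the scatter anyway. The data give no ground for expecting a move in either direction, so compound 4 is expected to sit close to compound 1 in this assay, with an estimated step of no change at the digits printed from compound 1 to compound 4 (within the scatter). Compound 4 is thus estimated at 50000 nM, with a range from 20000 nM to 100000 nM.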

Compound 4, concentration for 50% growth inhibition: 25000 nM
The estimate for compound 4 lay 2.0-fold (0.30 log units) above the measured number; low and high end bracket the measured number.
By their numbers in this assay, from the lowest: compounds 2, 3, 4 and 1 (each within the scatter of the next).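

In this assay, replacing 4-methylphenyl with 4-methoxyphenyl gives a 2.0-fold lower number from compound 1 to compound 4 (0.30 log units; within the scatter), so at this aromatic carbon, para to a large group, the exchange of methyl for methoxy produces no shift that can be read. Among these compounds, every earlier step altered the aromatic group on the double-bonded chain carbon, which makes this the first reading at this position, and it shows that the four compounds cannot be told apart whether the change is made there or here. No accompanying measurement bears on this result, and the data offer no explanation for it.

On these data alone, a single exchange at this position says little about its range, and it remains open whether an amine, a carboxylic acid or a longer chain such as ethoxy in the same place would move the number beyond the scatter. As far as these compounds go, it is also open whether methoxy would read the same alongside the 4-acetoxyphenyl group of compound 2 or the 4-hydroxy-3-nitrophenyl group of compound 3.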